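The compounds below may be only part of what the source reports. "The series", "measured", "known", "first", "only" and "open" are said of these compounds alone.

Working notes on the series. Three compounds have numbers in a functional assay on the whole organism (Tail, strain ICR) with Mus musculus as the target, in the tail flick test, with a stated time of 60 min, at a dose of 25 umol/kg by the oral route; a lower number here means a weaker effect, a higher number a stronger effect of the compound at the dose given. Compound 1 `O=C(CN(c1nc(Cl)nc2[nH]cnc12)C1CC1)N[C@@H](CO)C(=O)OCc1ccccc1` gives 34.2%; compound 3 `CSCC[C@H](NC(=O)CN(c1nc(Cl)nc2[nH]cnc12)C1CC1)C(=O)OCc1ccccc1` gives 30.8%; compound 2 `NC(=O)CC[C@H](NC(=O)CN(c1ncnc2c1ncn2C1CCCCO1)C1CC1)C(=O)OCc1ccccc1` gives 39.4%. Compound 2 carries the nominally highest of the three numbers, but its gap to compound 1 and its gap to compound 3 are both within the usual scatter, so the three stand together rather than in any order. Among the measured compounds shown here, the one measured step at the same position, a number 3.4 percentage points lower from compound 1 to compound 3 (within the scatter), exchanged a polar group for an alkyl one on the side chain and moved the read-out only within the scatter.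

Compound 4 `CC(C)C[C@H](NC(=O)CN(c1ncnc2c1ncn2C1CCCCO1)C1CC1)C(=O)OCc1ccccc1` is not yet measured in this assay. It differs from compound 2 by isopropyl in place of carbamoylmethyl on a saturated chain carbon, two bonds along the chain from an amide-type nitrogen and a carbonyl carbon. For the measured compounds named here, that change is of the same kind as the measured step from compound 1 to compound 3, a polar side chain giving way to an alkyl one, and that step was within the scatter; no other measured pair bears on the change. Accordingly, for compound 4 the expected step is a number 3.4 percentage points lower from compound 2 to compound 4 (within the scatter), none beyond the scatter. Compound 4 is therefore estimated at 36%, with a range from 20% to 52%.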

Compound 4, a percentage reported as activity, at one dose (the size of the read-out at that dose, not a potency): 34.2%
Beside the measured number, compound 4's estimate is 1.8 percentage points above it; the measured number falls inside the stated range.
By their numbers in this assay, from the lowest: compounds 3, 1, 4 and 2 (each within the scatter of the next).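

In this assay, isopropyl in place of carbamoylmethyl on this saturated chain carbon gives a number 5.2 percentage points lower from compound 2 to compound 4 (within the scatter), so losing the hydrogen-bond donor and acceptor of carbamoylmethyl leaves no readable change at this dose. Together with a number 3.4 percentage points lower from compound 1 to compound 3 (within the scatter), this gives two exchanges at the same position, on two different cores, and both stay within the scatter, so the flat picture no longer rests on a single pair. Nothing available gives a cause for this step.

Still open, as far as these compounds go, is whether a charged side chain, such as an amine or a carboxylic acid, or a longer chain at this position would give a step beyond the scatter. A single-dose read-out also leaves open whether compound 2 and compound 4 would stay together at other doses.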